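Swapping the Amide-Bearing Chain for a Pyridylmethyl Group

The compounds below may be only part of what the source reports. "The series", "measured", "known", "first", "only" and "open" are said of these compounds alone.

Going by the values given here, compound 2 `COc1ncc(-c2ccc3c(c2)N(CCC(=O)N2CCOCC2)C(=O)CO3)cc1NS(=O)(=O)c1ccc(F)cc1F` gives 3180 nM in a functional assay on HCT-116 cells (Homo sapiens) for antiproliferative activity, read by sulforhodamine B assay, with a stated time of 72 h (on this read-out higher numbers stand for weaker inhibition and lower numbers for stronger inhibition), the higher of the two numbers measured so far, while compound 1 `COc1ncc(-c2ccc3c(c2)N(Cc2ccc(F)cc2)C(=O)CO3)cc1NS(=O)(=O)c1ccc(F)cc1F` gives 1240 nM. Among the compounds with values here, the one step available, a 2.6-fold higher number from compound 1 to compound 2 (0.41 log units; beyond the scatter), went from an aromatic ring to the amide-bearing chain on a saturated chain carbon bound to an amide-type nitrogen in a ring. Compound 3 `COc1ncc(-c2ccc3c(c2)N(Cc2ccncc2)C(=O)CO3)cc1NS(=O)(=O)c1ccc(F)cc1F` moves back the other way: pyridin-4-yl in place of ((morpholin-4-yl)carbonyl)methyl on a saturated chain carbon bound to an amide-type nitrogen in a ring. Compound 3 is expected to show a 2.1-fold lower number from compound 2 to compound 3 (0.33 log units; beyond the scatter), because compound 1, carrying an aromatic ring at the same place, gave 1240 nM. Compound 3 is therefore estimated at 1500 nM, with a range from 600 nM to 4000 nM.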

Compound 3, half-maximal inhibitory concentration: 2220 nM
Compound 3: the middle estimate sits 1.5-fold (0.17 log units) below what was measured, within the range that was stated.
By their numbers in this assay, from the lowest: compounds 1, 3 and 2 (each within the scatter of the next, the first and the last beyond it).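

In this assay the change to pyridin-4-yl on a saturated chain carbon bound to an amide-type nitrogen in a ring separates compound 3 from neither neighbour: a 1.4-fold lower number from compound 2 to compound 3 (0.16 log units; within the scatter) and a 1.8-fold higher number from compound 1 to compound 3 (0.25 log units; within the scatter) both stay within the scatter. The gap between compound 1 and compound 2 is thus bridged by a group that cannot be placed on either side of it. Nothing at hand explains these numbers. On these data alone, whether a dimethylamino group, a carboxylic acid or a longer chain ending in pyridin-4-yl at this place would stand clearly apart from compound 1 stays open.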